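This account rests on a few compounds, and the source may have more. Where it says the series, first, only, none or still open, it means among the compounds named here.

Measured so far in an in vivo ADME assay on the whole organism (plasma) for pharmacokinetics, with Rattus norvegicus as the target, at a dose of 50 mg/kg by the oral route; a lower number here means less compound in the circulation, a higher number more compound in the circulation at the dose given:
- compound 1 `Cc1cc(C)c(NC(=O)c2sccc2S(=O)(=O)Nc2onc(C)c2Cl)c(C)c1` gives 81600 nM
- compound 2 `Cc1cc(C)c(NC(=O)c2sccc2S(=O)(=O)Nc2onc(C)c2Cl)c(C)c1CO` gives 5110 nM
- compound 3 `Cc1cc(C)c(NC(=O)c2sccc2S(=O)(=O)Nc2onc(C)c2Cl)c(C)c1C#N` gives 37200 nM

Compound 2 stands lowest of the three, and its steps to both others lie beyond the scatter. Compound 4 `Cc1cc(C)c(NC(=O)c2sccc2S(=O)(=O)Nc2onc(C)c2Cl)c(C)c1O` differs from it as follows: hydroxy in place of hydroxymethyl on an aromatic carbon. The nearest evidence is the large 16-fold lower number from compound 1 to compound 2 (1.20 log units; beyond the scatter) for adding hydroxymethyl, followed by the modest 2.2-fold lower number from compound 1 to compound 3 (0.34 log units; beyond the scatter) and the modest 7.3-fold higher number from compound 2 to compound 3 (0.86 log units; beyond the scatter) for cyano. From the compounds shown here alone, none of these steps places hydroxy on that carbon, so the direction stays open and no change beyond the scatter is expected. The expected result is a 1.2-fold higher number from compound 2 to compound 4 (0.07 log units; within the scatter) in this assay on this reading. Compound 4 is estimated at 6000 nM with an expected range from 1500 nM to 25000 nM at this dose.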

Compound 4, maximal plasma concentration: 106000 nM
Compound 4: middle estimate off by 18-fold (1.25 log units), on the low side, and the stated range ends below it.
By their numbers in this assay, from the lowest: compound 2; then compound 3; then compounds 1 and 4 (each within the scatter of the next).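

In this assay hydroxy and hydroxymethyl on this aromatic carbon are far apart, with a 21-fold higher number from compound 2 to compound 4 (1.32 log units; beyond the scatter), although both groups have the same hydrogen-bond donor and acceptor counts, so those counts alone do not set the number here. Hydroxy also separates from cyano, with a 2.8-fold higher number from compound 3 to compound 4 (0.45 log units; beyond the scatter), while a 1.3-fold higher number from compound 1 to compound 4 (0.11 log units; within the scatter) leaves it the only substituent shown that stays within the scatter of hydrogen. Nothing at hand accounts for the gap between hydroxy and hydroxymethyl. From the compounds shown here alone, whether methoxy or aminomethyl on this carbon would stay with hydroxy or drop towards hydroxymethyl remains open.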